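Configuration Changes on a Shared Core and Cytotoxic Potency

This account rests on a few compounds, and the source may have more. Where it says the series, first, only, none or still open, it means among the compounds named here.

Measured so far:
compound 1, `O=[N+]([O-])c1ccc(-c2ccc(S[C@@H]3O[C@H](CO)[C@H](O)[C@H](O)[C@H]3O)cc2)cc1`: 120000 nM
compound 2, `O=[N+]([O-])c1ccc(-c2ccc(S[C@@H]3O[C@H](CO)[C@@H](O)[C@H](O)[C@H]3O)cc2)cc1`: 250000 nM

Of the compounds shown here, two have been tested in a toxicity assay on PC-3 cells (Homo sapiens) for cytotoxicity, read by MTT assay, with a stated time of 2 h; on this read-out higher numbers stand for weaker inhibition and lower numbers for stronger inhibition. Compound 2 gives 250000 nM, the higher of the two numbers, and compound 1 gives 120000 nM. Going by the values given here, the single measured step between them is a 2.1-fold higher number from compound 1 to compound 2 (0.32 log units; beyond the scatter), a modest weakening; what links the two is the fact that compounds 1 and 2 differ only in the configuration as drawn.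

Compound 3, `O=[N+]([O-])c1ccc(-c2ccc(S[C@H]3O[C@H](CO)[C@@H](O)[C@H](O)[C@@H]3O)cc2)cc1`, has not yet been measured. Against compound 2 the difference is again purely one of configuration: the two compounds have the same atoms and bonds and differ only in configuration as drawn: 2 of 5 stereo elements differ; a stereocentre at a saturated ring carbon is drawn S in compound 2 and R in compound 3; a stereocentre at a saturated ring carbon is drawn R in compound 2 and S in compound 3. No atom leaves and none enters, so the comparison rests entirely on how the shared core is drawn in space.

Among the compounds with values here, the only guide is the step from compound 1 to compound 2, where a single change of configuration moved the number modestly. Compound 3 carries two such changes, and nothing measured tells whether they add up, cancel, or point in either direction. A step of about the same modest size, in either direction, is therefore the reasonable expectation, with a fair chance that it stays within the scatter.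

On that basis, compound 3 is expected to give about 200000 nM in this assay, somewhere between 80000 nM and 500000 nM. This estimate corresponds to an expected step of a 1.3-fold lower number from compound 2 to compound 3 (0.10 log units; within the scatter).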

Compound 3, half-maximal inhibitory concentration: 150000 nM
Estimate against measurement, compound 3: 1.3-fold (0.12 log units) above; measured number inside the range.
By their numbers in this assay, from the lowest: compounds 1, 3 and 2 (each within the scatter of the next, the first and the last beyond it).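

In this assay, a difference in drawn configuration at two saturated ring carbons gives a 1.7-fold lower number from compound 2 to compound 3 (0.22 log units; within the scatter), and a difference at three gives a 1.3-fold higher number from compound 1 to compound 3 (0.10 log units; within the scatter). A greater number of differing stereocentres therefore does not bring a greater step among these compounds: the single difference between compound 1 and compound 2 gives the only step beyond the scatter, while compound 3 stays within the scatter of both. Any comparison here concerns arrangement in space alone, since no atom or bond separates the compounds, as also holds for the latest pair: the fact that compounds 2 and 3 differ only in the configuration as drawn.

The compounds shown leave open what each stereocentre that differs in compound 3 does by itself, since those differences occur only together and their separate contributions cannot be read. They also leave open whether an amine or a carboxylic acid on the shared core would move the number further than any of these differences in configuration.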